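The source may hold more compounds than are shown below. What is called first, only, known or untested is meant among the compounds shown, and "the series" means these compounds.

Compound 2 `Clc1cccc(-c2nc3ccccc3[nH]2)n1` gives 30% in a functional assay on the whole organism with Rattus norvegicus as the target, read by paw edema, with a stated time of 3 h, at a dose of 100 mg/kg by the oral route; a lower number here means less inhibition, a higher number more inhibition at the dose given (going by the name of the read-out). Among the three compounds measured, compound 2 stands second highest: compound 1 `Cc1cccc(-c2nc3ccccc3[nH]2)n1` gives 44%, and compound 3 `NC(=O)c1cccc(-c2nc3ccccc3[nH]2)n1` gives 13%. Every measured step swaps the methyl, chloro or carbamoyl group, each on an aromatic carbon: a number 14 percentage points lower from compound 1 to compound 2 (beyond the scatter), a number 31 percentage points lower from compound 1 to compound 3 (beyond the scatter), and a number 17 percentage points lower from compound 2 to compound 3 (beyond the scatter). Each of these steps is beyond the scatter, and the carbamoyl compound is the lowest of the three.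

Compound 4 `Cc1ccc2[nH]c(-c3cccc(Cl)n3)nc2c1` differs from compound 2 at a different place, where the chloro group of compound 2 is kept: methyl in place of hydrogen on an aromatic carbon. For the measured compounds named here, none of the measured steps involves that place, so none of them bears directly on this change, and the data give no step of comparable kind to lean on. In the absence of any such guide, the addition of one carbon is expected to leave the number near where compound 2 stands, with no step beyond the scatter, and no change at the digits printed from compound 2 to compound 4 (within the scatter) is the step expected. Compound 4 is therefore estimated at 30% in this assay, with a range from 15% to 45%.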

Compound 4, a percentage reported as inhibition, in the whole organism at one dose (the size of the read-out at that dose, not a potency): 36%
Beside the measured number, compound 4's estimate is 6 percentage points below it; low and high end bracket the measured number.
By their numbers in this assay, from the lowest: compound 3; then compounds 2, 4 and 1 (each within the scatter of the next, the first and the last beyond it).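

With the chloro group of compound 2 kept, methyl in place of hydrogen on an aromatic carbon of the six-membered aromatic ring of carbon only gives a number 6 percentage points higher from compound 2 to compound 4 (within the scatter) in this assay. For the compounds shown here, this is the first reading at this place, since every earlier step changed the group at the chloro position instead. Those earlier steps all lay beyond the scatter, whereas this one does not, so the added methyl leaves the read-out at this single oral dose indistinguishable from that of compound 2, and the place accepts this one small group without a measurable change.

From the compounds shown here alone, it remains open whether a larger or different group at the same carbon, such as an ethyl chain, a methoxy group, an amine or a carboxylic acid, would also stay within the scatter, and whether the added methyl would behave the same way with the methyl of compound 1 or the carbamoyl of compound 3 in place of the chloro group. Nothing given here explains why the number holds at this place.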